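Two Methoxy Groups Replace a Fluorine and a Methoxy

A few compounds are considered here, and "the series" means these few. Any claim that something is new, unique, unknown or untested is made for them only; others in the source may bear on it.

Compound 1, `O=C(Nc1cccc(-c2oc3cc(-c4ccc(F)cc4)ccc3c(=O)c2O)c1)c1ccccc1F`, gives 10100 nM in a functional assay on HepG2 cells (Homo sapiens) for antiproliferative activity, read by CCK-8 assay, with a stated time of 72 h; a higher number here means a weaker inhibitor, a lower number a stronger inhibitor.
Compound 2, `Cc1ccc(C(=O)Nc2cccc(-c3oc4cc(-c5ccc(F)cc5)ccc4c(=O)c3O)c2)cc1`, gives 2320 nM in this assay.
Compound 3, `COc1ccc(C(=O)Nc2cccc(-c3oc4cc(-c5ccc(F)cc5)ccc4c(=O)c3O)c2)c(F)c1`, gives 45300 nM in this assay.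

Compound 3 stands highest of the three numbers, so it is the weakest inhibitor shown: the nearest is a 4.5-fold higher number from compound 1 to compound 3 (0.65 log units; beyond the scatter), and the furthest is a 20-fold higher number from compound 2 to compound 3 (1.29 log units; beyond the scatter). The unmeasured compound 4, `COc1cc(OC)cc(C(=O)Nc2cccc(-c3oc4cc(-c5ccc(F)cc5)ccc4c(=O)c3O)c2)c1`, differs from compound 3 only at the ring attached to the carbonyl carbon: 3,5-dimethoxyphenyl in place of 2-fluoro-4-methoxyphenyl on a carbonyl carbon.

Among the compounds with values here, two measured steps bear on this change, though neither matches it closely. Adding a methoxy to the ring gave a 4.5-fold higher number from compound 1 to compound 3 (0.65 log units; beyond the scatter), a modest weakening, whereas exchanging the whole ring gave a 4.4-fold lower number from compound 1 to compound 2 (0.64 log units; beyond the scatter). Within the data shown here, compound 4 removes the fluorine but carries two methoxy groups, so the steps pull in opposite directions and no measured pair shows this exact exchange. The expected result is therefore a small step in this assay, of uncertain direction, likely within the scatter: compound 4 is expected to show a 1.5-fold lower number from compound 3 to compound 4 (0.18 log units; within the scatter).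

The estimate for compound 4 in this assay is 30000 nM, with a range from 8000 nM to 100000 nM.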

Compound 4, half-maximal inhibitory concentration: 23500 nM
Beside the measured number, compound 4's estimate is 1.3-fold (0.11 log units) above it, within the range that was stated.
By their numbers in this assay, from the lowest: compound 2; then compound 1; then compounds 4 and 3 (each within the scatter of the next).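

In this assay, exchanging the 2-fluoro-4-methoxyphenyl ring for 3,5-dimethoxyphenyl on the carbonyl carbon gives a 1.9-fold lower number from compound 3 to compound 4 (0.29 log units; within the scatter) as its result, so this assay does not separate the two rings, even though one carries a fluorine and a single methoxy and the other carries two methoxy groups. The new ring also stays well apart from the simpler rings, with a 10-fold higher number from compound 2 to compound 4 (1.01 log units; beyond the scatter) against the 4-methylphenyl ring and a 2.3-fold higher number from compound 1 to compound 4 (0.37 log units; beyond the scatter) against the 2-fluorophenyl ring, so among these four compounds both rings bearing methoxy groups give higher numbers than both rings without one, and no compound here goes against that. Nothing available explains why the rings fall in this order.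

The compounds shown leave open whether a 4-methoxyphenyl ring, with no fluorine and no second methoxy, would fall with compound 3 and compound 4 or closer to compound 2. They also leave open whether a 4-ethylphenyl ring, or a ring carrying an amine or a carboxylic acid, would match or improve on compound 2, which gives 2320 nM in this assay as the lowest number here.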